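Piperidin-4-yl in Place of Pyridin-3-yl: Compound 4 Expected

This account rests on a few compounds, and the source may have more. Where it says the series, first, only, none or still open, it means among the compounds named here.

Three compounds sharing one core were tested in a functional assay on LNCaP cells (Homo sapiens) for antiproliferative activity, read by MTT assay, with a stated time of 24 h; a lower number here means a stronger inhibitor, a higher number a weaker inhibitor. Compound 1 `c1ccc(-c2noc(-c3ccncc3)n2)cc1` gives 710000 nM. For compound 2 `COc1ccc(-c2noc(-c3cccnc3)n2)cc1OC1CCCC1` the result is only a limit, > 1000000 nM. For compound 3 `COc1ccc(-c2noc(Cc3c[nH]c4ccccc34)n2)cc1OC1CCCC1` the result is likewise a limit, > 1000000 nM. Compound 2 thus stands at the limit of > 1000000 nM in this assay, at which 2 of the 3 values shown sit, without a number of its own. Compound 4 `COc1ccc(-c2noc(C3CCNCC3)n2)cc1OC1CCCC1` differs from compound 2 by piperidin-4-yl in place of pyridin-3-yl on an aromatic carbon. Within the data shown here, no measured pair differs in one place, so the size of such a step in this assay is not known from these data; the expectation is no step beyond the scatter, with compound 4 likely again at the limit. Compound 4 is estimated at 1000000 nM, between 300000 nM and 3000000 nM, which is expected to mean a number no higher from compound 2 to compound 4 (the limit leaves the size open).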

Compound 4, half-maximal inhibitory concentration: 10 nM
Compound 4: the middle estimate sits 100000-fold (5.00 log units) above what was measured; the measured number lies below the stated range.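

In this assay, piperidin-4-yl in place of pyridin-3-yl on the shared core gives an at least 100000-fold lower number from compound 2 to compound 4 (5.00 log units; beyond the scatter), the first step these data show at this position, and it is large. Both groups are six-membered rings, and what changes is a non-aromatic ring for an aromatic one, with a hydrogen-bond donor entering. The value of compound 2 is only a limit: the limit of > 1000000 nM in this assay, at which 2 of the 4 values shown sit.

The compounds shown leave open whether the non-aromatic ring or the hydrogen-bond donor goes with the step. A cyclohexyl ring and a piperidine with a methyl group on its nitrogen are not among them.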